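Fluorine on the Base Carbon of a Nucleoside Analogue

A few compounds are considered here, and "the series" means these few. Any claim that something is new, unique, unknown or untested is made for them only; others in the source may bear on it.

The two measured compounds share one core. Compound 1 `CC(=O)O[C@@H]1[C@@H](F)[C@@H](CSC(C)=O)O[C@H]1n1cc(C)c(=O)[nH]c1=O` carries a methyl on an aromatic carbon of the base, and in a functional assay on Caco-2 cells (Homo sapiens) for cytotoxicity, with a stated time of 72 h (on this read-out lower numbers stand for higher toxicity in this test and higher numbers for lower toxicity in this test), compound 1 gives 55500 nM. Compound 2 `CC(=O)O[C@@H]1[C@@H](F)[C@@H](CSC(C)=O)O[C@H]1n1ccc(=O)[nH]c1=O` carries a hydrogen there, and in this assay compound 2 gives 57800 nM. The step of a 1.0-fold higher number from compound 1 to compound 2 (0.02 log units; within the scatter) shows that this exchange left the read-out unchanged. Among the two numbers shown, compound 2 has the upper one, but its gap to compound 1 lies within the scatter, so the two count as equal. Compound 3 `CC(=O)O[C@@H]1[C@@H](F)[C@@H](CSC(C)=O)O[C@H]1n1cc(F)c(=O)[nH]c1=O` is not yet measured; it differs from compound 2 by fluoro in place of hydrogen on an aromatic carbon. For the measured compounds named here, only one measured step touches this position, the one from compound 1 to compound 2, and it stayed within the scatter. No step beyond the scatter is therefore expected here. Compound 3 is estimated at 57000 nM, with a range from 25000 nM to 130000 nM. That estimate means an expected 1.0-fold lower number from compound 2 to compound 3 (0.01 log units; within the scatter).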

Compound 3, half-maximal cytotoxic concentration: 54900 nM
Compound 3: middle estimate off by 1.0-fold (0.02 log units), on the high side; the measured number falls inside the stated range.
By their numbers in this assay, from the lowest: compounds 3, 1 and 2 (each within the scatter of the next).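

Fluoro now joins hydrogen and methyl on this aromatic carbon of the base, and in this assay the read-out does not respond to it: replacing hydrogen gives a 1.1-fold lower number from compound 2 to compound 3 (0.02 log units; within the scatter), and replacing methyl gives a 1.0-fold lower number from compound 1 to compound 3 (0.00 log units; within the scatter). Until now this position rested on a single exchange; with three different groups compared, compound 1, compound 2 and compound 3 all count as equal in this test, so the flat result is not limited to the methyl-to-hydrogen step. Nothing at hand explains why these exchanges leave the number in place.

Going by these compounds, it remains open whether an amine, a carboxylic acid or a longer chain at this position would move the number beyond the scatter. Changes elsewhere on the shared core also remain unread, as every compound here differs only at this one carbon.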